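Replacing a hydroxyethyl arm with an amino(ethylsulfanyl)methyl group

The compounds below may be only part of what the source reports. "The series", "measured", "known", "first", "only" and "open" are said of these compounds alone.

Compound 3 `Nc1nn2c(O)cc(CNCCO)nc2c1[N+](=O)[O-]` is one of three compounds that share one core. In a functional assay on K562 cells (Homo sapiens) for inhibition (on this read-out higher numbers stand for weaker inhibition of growth and lower numbers for stronger inhibition of growth), compound 3 gives only a limit, > 50 ug/mL, and not a number. Compound 1 `Nc1nn2c(O)cc(-c3ccccc3F)nc2c1[N+](=O)[O-]` likewise gives only a limit in this assay, > 50 ug/mL. Going by the values given here, compound 2 `Nc1nn2c(O)cc(CNNc3ccc(F)cc3)nc2c1[N+](=O)[O-]` is the one member with a number, giving 19.7 ug/mL in this assay. Among the compounds with values here, the step of an at least 2.5-fold higher number from compound 2 to compound 3 (0.40 log units; beyond the scatter) is therefore the one readable step, while a step that the two limits leave unreadable from compound 1 to compound 3; both limits sit at the limit of > 50 ug/mL in this assay, at which 2 of the 3 values shown sit.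

Compound 4 `CCSC(N)NCc1cc(O)n2nc(N)c([N+](=O)[O-])c2n1` differs from compound 3 in one place: amino(ethylsulfanyl)methyl in place of 2-hydroxyethyl on an amine nitrogen. Within the data shown here, no measured step swaps one chain on that amine nitrogen for another chain of this kind, so the only guide is that compound 3 itself sits at the limit. Compound 4 is therefore expected to stay near that limit, with a step of a number no higher from compound 3 to compound 4 (the limit leaves the size open), and its estimated value in this assay is 50 ug/mL, within a range from 15 ug/mL to 120 ug/mL.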

Compound 4, concentration for 50% growth inhibition: > 50 ug/mL
Compound 4: only a limit was reported; the forecaster's own chance of this, stated with the estimate: 60%; the middle value lies on the limit itself.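

Compound 4 gives only a limit in this assay, > 50 ug/mL, so a second chain on this amine nitrogen fails to give a number. Set against the one compound with a number, this is an at least 2.5-fold higher number from compound 2 to compound 4 (0.40 log units; beyond the scatter), which shows that amino(ethylsulfanyl)methyl, like 2-hydroxyethyl, does not match (4-fluorophenyl)amino at this place. The steps to compound 4 from compound 1 and from compound 3 join two limits and cannot be read.

Going by these compounds, whether a benzyl group or a longer alkyl chain on that amine nitrogen would bring back a number stays open. How far compound 3 and compound 4 lie apart also stays open, because so many values share one limit: the limit of > 50 ug/mL in this assay, at which 3 of the 4 values shown sit.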